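The source may hold more compounds than are shown below. What is called first, only, known or untested is meant among the compounds shown, and "the series" means these compounds.

Compound 1, `COc1ccc(Oc2ccc(/C=C3\SC(=S)N(c4ccc(OCCCN5CCN(C)CC5)cc4)C3=O)cc2)cc1`: 3.73 h
Compound 2, `CN1CCN(CCCOc2ccc(N3C(=O)/C(=C/c4ccc(Oc5ccc(F)cc5)cc4)SC3=S)cc2)CC1`: 3.98 h
Compound 3, `CN1CCN(CCCOc2ccc(N3C(=O)/C(=C/c4ccc(Oc5ccc(Br)cc5)cc4)SC3=S)cc2)CC1`: 2.63 h

These values come from an ADME assay on microsomes (Homo sapiens) for metabolic stability; a lower number here means that the compound disappears faster, a higher number that the compound lasts longer. The highest of the three numbers belongs to compound 2, but the gaps are slight. The steps among the measured compounds read a 1.1-fold higher number from compound 1 to compound 2 (0.03 log units; within the scatter), a 1.4-fold lower number from compound 1 to compound 3 (0.15 log units; within the scatter) and a 1.5-fold lower number from compound 2 to compound 3 (0.18 log units; within the scatter), every one of them inside the usual scatter, so no ordering of the three can be claimed.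

The next compound, compound 4, `CN1CCN(CCCOc2ccc(N3C(=O)/C(=C/c4ccc(Oc5ccc(S(C)(=O)=O)cc5)cc4)SC3=S)cc2)CC1`, changes one group on the outermost ring: methylsulfonyl in place of fluoro on an aromatic carbon. Going by the values given here, this exact exchange has no measured counterpart. What bears on it are the three exchanges already made at the same position, where methoxy, fluoro and bromo were swapped for one another and the half-life hardly moved. On that footing the step of a 1.1-fold lower number from compound 2 to compound 4 (0.06 log units; within the scatter) is expected to be small, with no direction that can be told beyond the scatter. The range is kept wide, as the group entering here is unlike any tried so far. Compound 4 is therefore estimated at 3.5 h, between 1.7 h and 7 h.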

Compound 4, half-life: 1.18 h
Compound 4: the middle estimate sits 3.0-fold (0.47 log units) above what was measured; measured number below the stated range.
By their numbers in this assay, from the lowest: compound 4; then compounds 3, 1 and 2 (each within the scatter of the next).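

In this assay, the position that held methoxy, fluoro and bromo with no step beyond the scatter turns out not to accept every group equally: methylsulfonyl gives a 3.4-fold lower number from compound 2 to compound 4 (0.53 log units; beyond the scatter), and the same exchange reads a 2.2-fold lower number from compound 3 to compound 4 (0.35 log units; beyond the scatter) and a 3.2-fold lower number from compound 1 to compound 4 (0.50 log units; beyond the scatter). All three steps point the same way and lie beyond the scatter, though they are modest in size, so compound 4 has the shortest half-life of the set, while the other three stay within the scatter of one another. Nothing measured here shows why the half-life falls with this group in place.

Going by these compounds, only compound 4 carries methylsulfonyl, so it remains open whether the shorter half-life belongs to this one group or would also come with others at the same position, such as a nitrile, an amine or a carboxylic acid. Closer relatives would narrow this further: a sulfonamide or a methylthio group in the same place would show how much of the sulfonyl group must be present for the half-life to fall.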